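This account rests on a few compounds, and the source may have more. Where it says the series, first, only, none or still open, it means among the compounds named here.

Compound 1 `NC(=S)Nc1cccc(OCCCCCc2ccccc2)c1` in an ADME assay on Ava5 cells (Homo sapiens) for cytotoxicity (on this read-out lower numbers stand for higher toxicity in this test and higher numbers for lower toxicity in this test), gives 22000 nM.
Compound 2 `CNC(=S)Nc1cccc(OCCCCCc2ccccc2)c1` in this assay gives > 50000 nM, which is a limit of the test and not a number.
Compound 3 `S=C(Nc1ccccc1)Nc1cccc(OCCCCCc2ccccc2)c1` in this assay gives 35000 nM.

These three share one core and differ only in the group on the amide-type nitrogen next to the thiocarbonyl carbon. Of the two numbers, compound 1 and compound 3 sit within the scatter of each other: a 1.6-fold higher number from compound 1 to compound 3 (0.20 log units; within the scatter). The step from methyl to phenyl also reads an at least 1.4-fold lower number from compound 2 to compound 3 (0.15 log units; that floor lies within the scatter), a floor that lies within the scatter, while the step to the methyl compound, an at least 2.2-fold higher number from compound 1 to compound 2 (0.35 log units; beyond the scatter), is the only one beyond it.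

Compound 4 `S=C(NCc1ccccc1)Nc1cccc(OCCCCCc2ccccc2)c1` differs from compound 3 by benzyl in place of phenyl on an amide-type nitrogen. The two steps that bear on this position, a 1.6-fold higher number from compound 1 to compound 3 (0.20 log units; within the scatter) and an at least 1.4-fold lower number from compound 2 to compound 3 (0.15 log units; that floor lies within the scatter), both stayed within the scatter, so no step beyond the scatter is expected in this assay in either direction. Compound 4 is therefore estimated at 38000 nM, between 19000 nM and 76000 nM, an expected step of a 1.1-fold higher number from compound 3 to compound 4 (0.04 log units; within the scatter). Because of the limit of > 50000 nM in this assay, at which 1 of the 3 values shown sits, the result for compound 4 may also come back only as a limit.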

Compound 4, half-maximal cytotoxic concentration: 32000 nM
Beside the measured number, compound 4's estimate is 1.2-fold (0.07 log units) above it, within the range that was stated.
By their numbers in this assay, from the lowest: compounds 1, 4 and 3 (each within the scatter of the next). At a limit, above all of these: compound 2.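

In this assay, benzyl in place of phenyl on the amide-type nitrogen stays within the scatter (a 1.1-fold lower number from compound 3 to compound 4 (0.04 log units; within the scatter)). Benzyl in place of hydrogen at this place also stays within it (a 1.5-fold higher number from compound 1 to compound 4 (0.16 log units; within the scatter)), so neither aromatic group shown here separates from the compound carrying hydrogen, and the methyl compound remains the only one beyond the scatter of that compound. Compound 2 carries a limit and not a number, so its step gives only a floor that lies within the scatter (an at least 1.5-fold lower number from compound 2 to compound 4 (0.19 log units; that floor lies within the scatter)): (the limit of > 50000 nM in this assay, at which 1 of the 4 values shown sits).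

The compounds shown leave open whether phenethyl, a carboxylic acid or a chain ending in an amine on this nitrogen would give a step beyond the scatter. They also leave open where the actual number for compound 2 lies.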